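Replacing the Sulfonamide Aryl Cap: Cytotoxicity Expectation

The compounds below may be only part of what the source reports. "The series", "measured", "known", "first", "only" and "open" are said of these compounds alone.

Three analogues sharing one core have been measured in an ADME assay on HepG2 cells (Homo sapiens) for cytotoxicity; on this read-out higher numbers stand for an effect only at larger amounts of compound and lower numbers for an effect already at smaller amounts. Compound 1 `Cc1ccc(S(=O)(=O)N[C@@H](CC(=O)NC(C)(C)C)C(=O)NCCNS(=O)(=O)c2ccccc2)cc1` reaches only the limit of > 11000 nM in this assay. Compound 2 `Cc1ccc(S(=O)(=O)N[C@@H](CC(=O)NC(C)(C)C)C(=O)NCCNC(=O)c2cccc(C(C)C)c2)cc1` likewise sits at the limit of > 11000 nM. Compound 3 `Cc1ccc(S(=O)(=O)N[C@@H](CC(=O)NC(C)(C)C)C(=O)NCCNC(=O)c2cc(C)ccn2)cc1` also gives the limit value > 11000 nM. The steps a step that the two limits leave unreadable from compound 1 to compound 2, a step that the two limits leave unreadable from compound 1 to compound 3 and a step that the two limits leave unreadable from compound 2 to compound 3 all remain unreadable because of the limit of > 11000 nM in this assay, at which 3 of the 3 values shown sit. Compound 4 `Cc1ccc(S(=O)(=O)N[C@@H](CC(=O)NC(C)(C)C)C(=O)NCCNC(=O)c2cccc(C#N)c2)cc1` differs from compound 1 by (3-cyanophenyl)carbonyl in place of phenylsulfonyl on an amine nitrogen. The related steps offer no readable size, and every measured value rests at the same limit. Compound 4 is therefore expected to show a number no higher from compound 1 to compound 4 (the limit leaves the size open), no step beyond the scatter. The value of compound 4 in this assay is estimated at 11000 nM, ranging from 5000 nM to 30000 nM, most likely reported again as a limit.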

Compound 4, half-maximal effective concentration: > 11000 nM
Compound 4 ended at the assay's limit; the forecaster's own chance of this, stated with the estimate: 85%; the middle value sits exactly at the limit.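

The steps linking compound 4 with compound 1, compound 2 and compound 3 cannot be read in this assay because all four compounds rest at one limit: the limit of > 11000 nM in this assay, at which 4 of the 4 values shown sit. The compounds shown leave open whether the groups on the amine nitrogen differ at all in this read-out.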